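This account rests on a few compounds, and the source may have more. Where it says the series, first, only, none or still open, it means among the compounds named here.

Compounds measured in an assay on RBL cells for inhibition of Polyunsaturated fatty acid 5-lipoxygenase (Rattus norvegicus); on this read-out lower numbers stand for stronger inhibition and higher numbers for weaker inhibition:
compound 1, `CC(=O)N(O)C(C)c1ccc2oc(-c3ccccc3)cc2c1`, gives 490 nM;
compound 2, `COc1ccc(C(=O)N(O)C(C)c2ccc3oc(-c4ccccc4)cc3c2)cc1OC`, gives 200 nM;
compound 3, `CC(c1ccc2oc(-c3ccccc3)cc2c1)N(O)C(=O)c1cccs1`, gives 250 nM.

Compound 3 stands second highest of the three numbers. Among the measured compounds shown here, the steps that reach it are a 1.3-fold higher number from compound 2 to compound 3 (0.10 log units; within the scatter) and a 2.0-fold lower number from compound 1 to compound 3 (0.29 log units; within the scatter), both within the scatter; the only step beyond the scatter is a 2.5-fold lower number from compound 1 to compound 2 (0.39 log units; beyond the scatter).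

Compound 4, `COC(=O)CCCC(=O)N(O)C(C)c1ccc2oc(-c3ccccc3)cc2c1`, is the next step and is not yet measured in this assay. The change is 3-(methoxycarbonyl)propyl in place of thiophen-2-yl on a carbonyl carbon. All three measured steps vary the same position on the carbonyl carbon: methyl to an aromatic ring gave a 2.5-fold lower number from compound 1 to compound 2 (0.39 log units; beyond the scatter) and a 2.0-fold lower number from compound 1 to compound 3 (0.29 log units; within the scatter), and one ring to another gave a 1.3-fold higher number from compound 2 to compound 3 (0.10 log units; within the scatter). For the measured compounds named here, no measured step replaces a ring by a chain, so the present change is not directly covered. Given that the methyl compound 1 sits highest and the ring compounds lower, the expectation for compound 4 is a number between those of compound 3 and compound 1, meaning a step of a 1.6-fold higher number from compound 3 to compound 4 (0.20 log units; within the scatter), probably within the scatter. Compound 4 is therefore estimated at 400 nM, with a range from 150 nM to 1100 nM.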

Compound 4, half-maximal inhibitory concentration: 60 nM
Beside the measured number, compound 4's estimate is 6.7-fold (0.82 log units) above it; measured number outside the range, below it.
By their numbers in this assay, from the lowest: compound 4; then compounds 2, 3 and 1 (each within the scatter of the next, the first and the last beyond it).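

In this assay, 3-(methoxycarbonyl)propyl in place of a ring on the carbonyl carbon gives a 4.2-fold lower number from compound 3 to compound 4 (0.62 log units; beyond the scatter) and a 3.3-fold lower number from compound 2 to compound 4 (0.52 log units; beyond the scatter), so a low number at this position does not depend on an aromatic ring. Among the compounds shown here, compound 4 has the lowest number of the four, and its steps to all three others lie beyond the scatter; the step of an 8.2-fold lower number from compound 1 to compound 4 (0.91 log units; beyond the scatter) is also larger than any step among the earlier compounds. Nothing available bears on what lies behind this result.

The compounds shown do not separate the contribution of the chain from that of its terminal methyl ester. From the compounds shown here alone, a plain butyl chain, the corresponding carboxylic acid, and shorter or longer ester chains would each test this, and how any of them would read here remains open.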